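Pyrrolidine to propylamino on a thiocarbonyl carbon

The source may report more compounds than this note shows. Statements on the series, on what has been measured and on what is new or still open speak of the compounds shown alone.

Measured in a functional assay on SGC-7901 cells (Homo sapiens) for cytotoxicity, read by MTT assay, with a stated time of 72 h; a lower number here means a stronger inhibitor, a higher number a weaker inhibitor:
compound 1 `Oc1ccc(C2C/C(=N\NC(=S)N3CCCC3)c3ccc(O)cc3O2)cc1` gives 37000 nM
compound 2 `CCCCNC(=S)N/N=C1\CC(c2ccc(O)cc2)Oc2cc(O)ccc21` gives 50800 nM

Compound 1 has a single measured neighbour on these numbers, and no gap beyond the scatter separates the two. Compound 3 `CCCNC(=S)N/N=C1\CC(c2ccc(O)cc2)Oc2cc(O)ccc21` has not yet been measured. Within the data shown here, it keeps the core of compound 1 and carries propylamino in place of pyrrolidin-1-yl on a thiocarbonyl carbon as its only change. Among the measured compounds shown here, one measured step bears on this, since butylamino replaces pyrrolidin-1-yl at that same carbon, and it amounts to a 1.4-fold higher number from compound 1 to compound 2 (0.14 log units; within the scatter) in all. No shift beyond the scatter is therefore expected in this assay for this change. The estimated step is a 1.2-fold higher number from compound 1 to compound 3 (0.09 log units; within the scatter) and it is expected to remain small. Compound 3 is estimated at 45000 nM with an expected range of 22000 nM to 90000 nM.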

Compound 3, half-maximal inhibitory concentration: 31200 nM
For compound 3 the middle estimate is 1.4-fold (0.16 log units) above the measured one; the range from low to high includes it.
By their numbers in this assay, from the lowest: compounds 3, 1 and 2 (each within the scatter of the next).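

In this assay, the step of a 1.2-fold lower number from compound 1 to compound 3 (0.07 log units; within the scatter) shows that a second open chain in place of pyrrolidin-1-yl on the thiocarbonyl carbon also stays within the scatter, even though this change removes the ring and adds a hydrogen-bond donor to the count. Among these compounds, the step of a 1.6-fold lower number from compound 2 to compound 3 (0.21 log units; within the scatter) adds a comparison the earlier compounds could not give, between two open chains, and removing one chain carbon from butylamino to give propylamino also stays within the scatter. Nothing at hand offers an explanation for these small steps.

Pyrrolidin-1-yl, butylamino and propylamino therefore cannot be told apart in this assay, and no group shown at this carbon moves the number beyond the scatter. Going by these compounds, whether a much longer chain, a phenylamino group or a morpholin-4-yl ring would do so remains open.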